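Swapping the Triazolyl Sulfide for an Ethylpiperazine

This account rests on a few compounds, and the source may have more. Where it says the series, first, only, none or still open, it means among the compounds named here.

Compound 3 `Cn1cnnc1SCC(=O)Nc1ccc(-c2nc(-c3ccccc3)c(-c3ccccc3)n2C)cc1` stands highest of the three compounds measured in a functional assay on HT-29 cells (Homo sapiens) for cytotoxicity, read by MTT assay, with a stated time of 24 h, tested at 6.4 ug/mL (a lower number here means a weaker effect, a higher number a stronger effect of the compound at the concentration tested), where compound 3 gives 43.1%. Compound 2 `Cn1c(-c2ccc(NC(=O)CSc3nc4cc(Cl)ccc4o3)cc2)nc(-c2ccccc2)c1-c1ccccc1` gives 29.4% in this assay, and compound 1 `Cn1c(-c2ccc(NC(=O)CCl)cc2)nc(-c2ccccc2)c1-c1ccccc1` gives 15.1%. Both steps up to compound 3, a number 13.7 percentage points higher from compound 2 to compound 3 (beyond the scatter) and a number 28 percentage points higher from compound 1 to compound 3 (beyond the scatter), lie beyond the scatter, so compound 3 is the most active of the three. Compound 4 `CCN1CCN(CC(=O)Nc2ccc(-c3nc(-c4ccccc4)c(-c4ccccc4)n3C)cc2)CC1` has not yet been measured in this assay. Its difference from compound 3 is 4-ethylpiperazin-1-yl in place of (4-methyl-4H-1,2,4-triazol-3-yl)sulfanyl on a saturated chain carbon bound to a carbonyl carbon.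

Every measured step in this set concerns the same place on the saturated chain carbon bound to the carbonyl carbon. The step of a number 14.3 percentage points higher from compound 1 to compound 2 (beyond the scatter) and the step of a number 28 percentage points higher from compound 1 to compound 3 (beyond the scatter) both show that a sulfur-linked aromatic heterocycle at this place raises the number over a plain chloro, and a number 13.7 percentage points higher from compound 2 to compound 3 (beyond the scatter) shows that the two heterocycles differ from each other. Among the compounds with values here, no measured compound carries a non-aromatic ring such as 4-ethylpiperazin-1-yl at this place, so the data offer no direct precedent for compound 4. Given that the largest measured values came with the sulfur-linked groups, a modest downward step is expected, with wide uncertainty: the estimate for compound 4 is 30%, between 10% and 55%, which means an expected step of a number 13.1 percentage points lower from compound 3 to compound 4 (beyond the scatter).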

Compound 4, a percentage reported as activity, at one concentration (the size of the read-out at that concentration, not a potency): 17.2%
For compound 4 the middle estimate is 12.8 percentage points above the measured one; the measured number falls inside the stated range.
By their numbers in this assay, from the lowest: compounds 1 and 4 (each within the scatter of the next); then compound 2; then compound 3.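

In this assay, putting 4-ethylpiperazin-1-yl on the saturated chain carbon bound to the carbonyl carbon gives a number a number 25.9 percentage points lower from compound 3 to compound 4 (beyond the scatter), and the comparison with the benzoxazole compound gives a number a number 12.2 percentage points lower from compound 2 to compound 4 (beyond the scatter), so both sulfur-linked aromatic heterocycles stand clear of this non-aromatic ring. Against the plain chloro, the change gives a number 2.1 percentage points higher from compound 1 to compound 4 (within the scatter), and the two compounds cannot be told apart in this read-out. Replacing chloro at this place therefore does not raise the number in every case: among these four compounds, the rise comes with compound 2 and compound 3, while compound 4 goes against any general gain from a larger group. The data on hand offer no explanation for these differences.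

The compounds shown do not separate the sulfur link from the aromatic ring, so it remains open whether a triazole joined directly through a ring nitrogen, or a piperazine joined through sulfur, would follow compound 3 or compound 4. As far as these compounds go, it also remains open whether a morpholine or a simple dimethylamine at this place would read like 4-ethylpiperazin-1-yl, and whether this order would hold at other concentrations.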